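Exchanging One Group on Compound 1

The source may hold more compounds than are shown below. What is called first, only, known or untested is meant among the compounds shown, and "the series" means these compounds.

In an ADME assay on HEK-293T cells (Homo sapiens) for cytotoxicity, read by CCK-8 assay, with a stated time of 48 h (on this read-out higher numbers stand for weaker inhibition and lower numbers for stronger inhibition), compound 1 `O=C(NCCNS(=O)(=O)c1ccc(-c2ccccc2O[C@H]2CC[C@H](O)CC2)s1)Nc1ccc([N+](=O)[O-])cc1` gives 9000 nM. Compound 2 `O=C(NCCNS(=O)(=O)c1ccc(-c2ccccc2Oc2ccc([N+](=O)[O-])c([N+](=O)[O-])c2)s1)Nc1ccc([N+](=O)[O-])cc1` gives 16600 nM, which lies within the scatter of compound 1. Compound 3 `Cc1cc(C)cc(NC(=O)NCCNS(=O)(=O)c2ccc(-c3ccccc3OCc3ccccc3)s2)c1` shows > 20000 nM, and this is a limit of the assay. Compound 1 therefore sits level with compound 2 among the two actual numbers.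

Compound 4 `O=[N+]([O-])c1ccc(NC(=S)NCCNS(=O)(=O)c2ccc(-c3ccccc3O[C@H]3CC[C@H](O)CC3)s2)cc1` has not yet been measured in this assay. It differs from compound 1 in a single exchange: a group of 12 heavy atoms (7 carbon, 2 nitrogen, 2 oxygen, 1 sulfur; one six-membered aromatic ring of carbon only) in place of a group of 12 heavy atoms (7 carbon, 2 nitrogen, 3 oxygen; one six-membered aromatic ring of carbon only), on an amine nitrogen.

Among the compounds with values here, no measured step covers this exchange. The only one available, a 1.8-fold higher number from compound 1 to compound 2 (0.27 log units; within the scatter), concerns a different place, the group on an oxygen on an aromatic ring, so it bears on the question only indirectly. It shows that compound 1 and compound 2 stay close despite that replacement, but it says nothing about the sulfur-bearing group. With so little to go on, no shift beyond the scatter is expected, and the expected step is a 1.1-fold lower number from compound 1 to compound 4 (0.05 log units; within the scatter).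

For compound 4 the estimated value is 8000 nM, with an expected range of 3500 nM to 18000 nM.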

Compound 4, half-maximal inhibitory concentration: 10500 nM
Estimate against measurement, compound 4: 1.3-fold (0.12 log units) below; low and high end bracket the measured number.
By their numbers in this assay, from the lowest: compounds 1, 4 and 2 (each within the scatter of the next). At a limit, above all of these: compound 3.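

Within the data shown here, the first step at this place, on an amine nitrogen whose other neighbours are a saturated chain carbon, stays within the scatter in this assay (a 1.2-fold higher number from compound 1 to compound 4 (0.07 log units; within the scatter)). The group with one sulfur thus takes the place of (4-nitrophenyl)carbamoyl with no shift that this read-out can separate from repeat variation, whereas the earlier step concerned only the group on an oxygen on an aromatic ring. Nothing measured here bears on a cause for this result.

From the compounds shown here alone, what an acetyl group or a longer alkyl chain would give on this amine nitrogen remains open, since both groups at this place carry the same aromatic ring. Going by these compounds, it is also open whether the sulfur-bearing group would stay as close with 3,4-dinitrophenyl on the oxygen.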